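This account rests on a few compounds, and the source may have more. Where it says the series, first, only, none or still open, it means among the compounds named here.

Measured in a functional assay on KB cells (Homo sapiens) for antiproliferative activity, read by sulforhodamine B assay, with a stated time of 3 days; on this read-out higher numbers stand for an effect only at larger amounts of compound and lower numbers for an effect already at smaller amounts:

compound 1, `CCC1=C(O)c2c(oc(-c3ccc(OC)c(Cl)c3)cc2=O)C(CC)(CC)C1=O`, 24.9 uM
compound 2, `CCC1=C(O)c2c(oc(-c3ccc(OC)c(OC)c3OC)cc2=O)C(CC)(CC)C1=O`, 9.4 uM
compound 3, `CCC1=C(O)c2c(oc(-c3cc(Cl)c(OC)c(OC)c3)cc2=O)C(CC)(CC)C1=O`, 21.8 uM

Compound 2 stands lowest of the three, and its gaps to compound 3 and to compound 1 are beyond the scatter. The difference between the cores of compound 2 and compound 3 is not broken down here. Between compound 3 and compound 1 the change is hydrogen in place of methoxy on an aromatic carbon, and it gave a 1.1-fold higher number from compound 3 to compound 1 (0.06 log units; within the scatter).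

Compound 4, `CCC1=C(O)c2c(oc(-c3cccc(OC)c3OC)cc2=O)C(CC)(CC)C1=O`, is not yet measured. It arises from compound 2 by the same kind of change, (hydrogen in place of methoxy on an aromatic carbon), but the surroundings differ: here the carbon is meta to a methoxy group and para to a large group, whereas in compound 1 it is meta to a chloro group and meta to a large group.

Because the earlier step of a 1.1-fold higher number from compound 3 to compound 1 (0.06 log units; within the scatter) was small, a similar step is expected, yet the distinct standing of compound 2 leaves room for some loss. For compound 4 the estimated step is a 1.6-fold higher number from compound 2 to compound 4 (0.20 log units; within the scatter). Compound 4 is expected at 15 uM, between 7 uM and 35 uM.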

Compound 4, concentration for half-maximal effect: 35.2 uM
For compound 4 the middle estimate is 2.3-fold (0.37 log units) below the measured one; measured number outside the range, above it.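

In this assay, hydrogen in place of methoxy on an aromatic carbon gives a 3.7-fold higher number from compound 2 to compound 4 (0.57 log units; beyond the scatter). The change does not carry over with a constant size between these two cores: the same change on two cores in this assay, a 1.1-fold higher number (0.06 log units; within the scatter) from compound 3 to compound 1 and a 3.7-fold higher number (0.57 log units; beyond the scatter) from compound 2 to compound 4, 3.3-fold (0.52 log units) apart, beyond the scatter of two such steps

Two steps set no rule for the series, and they do not tell whether the surroundings of the changed carbon or the rest of the core account for the gap. The compounds shown leave open how an amine or a carboxylic acid would read in place of the methoxy group at this carbon. They also leave open whether the same change keeps its size when a longer chain replaces the ethyl groups on the shared core.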